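Lipophilicity note on the pendant phenyl variation

The source may hold more compounds than are shown below. What is called first, only, known or untested is meant among the compounds shown, and "the series" means these compounds.

For the measured compounds named here, compound 2 `COc1ccc(Cl)cc1-n1ncc(-c2nnc(-c3cccc(F)c3)o2)c1C` is the lower of the two measured members in a physicochemical assay for lipophilicity, using the shake flask method, measured as octanol-water partition; on this read-out lower numbers stand for lower lipophilicity and higher numbers for higher lipophilicity; in this assay compound 2 gives 4.28, whereas compound 1 `COc1ccc(Cl)cc1-n1ncc(-c2nnc(-c3ccc(Br)cc3)o2)c1C` gives 4.88. Going by the values given here, the single measured step is a number 0.60 log units lower from compound 1 to compound 2 (beyond the scatter), and it concerns only the halogenated phenyl ring on the five-membered aromatic ring with 2 nitrogen and 1 oxygen.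

Compound 3 `COc1ccc(Cl)cc1-n1ncc(-c2nnc(-c3cc(Cl)cc(Cl)c3)o2)c1C` differs from compound 2 at that same place: 3,5-dichlorophenyl in place of 3-fluorophenyl on an aromatic carbon. Among the compounds with values here, no measured pair exchanges fluorine for chlorine or adds a second halogen, so the step from compound 1 to compound 2 bears on the question only as the one recorded variation of this ring. Since a single fluorine in place of bromine lowered the number by a number 0.60 log units lower from compound 1 to compound 2 (beyond the scatter), two chlorines in place of one fluorine are expected to move the number the other way, and by somewhat more.

Compound 3 is therefore expected to give 5.4, with a range from 4.9 to 5.9. The expected step is a number 1.12 log units higher from compound 2 to compound 3 (beyond the scatter), which would lie beyond the scatter.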

Compound 3, partition coefficient: 5.61
Estimate against measurement, compound 3: 0.21 log units below; the range from low to high includes it.
By their numbers in this assay, from the lowest: compound 2; then compound 1; then compound 3.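

Working notes on the halogenated phenyl place: the range in this assay at this one place is wider than the first pair showed, with a number 1.33 log units higher from compound 2 to compound 3 (beyond the scatter) printed as a large step, whereas the only earlier step was modest. The number also moves past the 4-bromophenyl member, with a number 0.73 log units higher from compound 1 to compound 3 (beyond the scatter) as the second new step, so the earlier pair's single downward move does not set the upper end at this place, and compound 3 now stands highest of the three, beyond the scatter from both others. No supporting information accompanies these values to account for the size of either step.

Each of the three phenyl groups differs from the others in both the kind and the number of halogens, so the contribution of halogen identity cannot be separated from that of halogen count, and a 3-chlorophenyl or an unsubstituted phenyl would be needed to separate them. From the compounds shown here alone, how far the number falls below the value of compound 2 with a non-halogen group on this ring, such as an amine or a carboxylic acid, also remains open.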